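Methoxy position swap on the aryl hydrazone

The source may hold more compounds than are shown below. What is called first, only, known or untested is meant among the compounds shown, and "the series" means these compounds.

Measured so far:
compound 1 `CN(C)CCn1cnnc1-c1cc(Oc2ccc(NC(=O)N/N=C/c3ccc(Cl)cc3Cl)cc2F)ccn1` gives 810 nM in a functional assay on A549 cells (Homo sapiens) for cytotoxicity, read by MTT assay, with a stated time of 72 h; a lower number here means a stronger inhibitor, a higher number a weaker inhibitor
compound 2 `COc1ccc(OC)c(/C=N/NC(=O)Nc2ccc(Oc3ccnc(-c4nncn4CCN(C)C)c3)c(F)c2)c1` gives 1950 nM

Compound 2 carries the higher of the two numbers; its nearest neighbour is compound 1, the gap being a 2.4-fold higher number from compound 1 to compound 2 (0.38 log units; beyond the scatter). Compound 3 `COc1ccc(/C=N/NC(=O)Nc2ccc(Oc3ccnc(-c4nncn4CCN(C)C)c3)c(F)c2)c(OC)c1` differs from compound 2 only in that (2,4-dimethoxyphenyl in place of 2,5-dimethoxyphenyl on a carbon with a double bond to nitrogen). For the measured compounds named here, the one measured step exchanges the whole aryl group for a different one and does not speak to moving a single methoxy; no measured step bears directly on this change. The expected step is therefore small, within the scatter, a 1.1-fold lower number from compound 2 to compound 3 (0.03 log units; within the scatter). For compound 3 the estimate in this assay is 1800 nM, with a range from 900 nM to 3600 nM.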

Compound 3, half-maximal inhibitory concentration: 2820 nM
Beside the measured number, compound 3's estimate is 1.6-fold (0.19 log units) below it; the range from low to high includes it.
By their numbers in this assay, from the lowest: compound 1; then compounds 2 and 3 (each within the scatter of the next).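

In this assay the 2,4-dimethoxyphenyl in place of the 2,5-dimethoxyphenyl gives a 1.4-fold higher number from compound 2 to compound 3 (0.16 log units; within the scatter) and so does not separate these two methoxy arrangements at this place. With the pattern held constant, replacing the 2,4-dichlorophenyl with the 2,4-dimethoxyphenyl gives a 3.5-fold higher number from compound 1 to compound 3 (0.54 log units; beyond the scatter) and isolates the exchange of chlorine for methoxy from any change of pattern. No available evidence accounts for either step.

The compounds shown carry only chlorine and methoxy on this phenyl ring. As far as these compounds go, whether a single methoxy, an amine or a carboxylic acid there would change the number remains open.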